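From tert-butyl to isobutyl on an amide-type nitrogen

The compounds below may be only part of what the source reports. "The series", "measured", "known", "first", "only" and "open" are said of these compounds alone.

Compound 1 `Nc1sc(-c2ccc(Cl)cc2)c(-c2ccc(Cl)cc2)c1C(=O)Nc1ccccc1`: 25000 nM
Compound 2 `CC(C)(C)NC(=O)c1c(N)sc(-c2ccc(Cl)cc2)c1-c1ccc(Cl)cc1`: 8850 nM

Within the data shown here, in a functional assay on A549 cells (Homo sapiens) for inhibition, read by sulforhodamine B assay, with a stated time of 72 h (on this read-out lower numbers stand for stronger inhibition and higher numbers for weaker inhibition), compound 2 gives 8850 nM, the lower of the two numbers measured so far, and compound 1 stands higher at 25000 nM. Compound 3 `CC(C)CNC(=O)c1c(N)sc(-c2ccc(Cl)cc2)c1-c1ccc(Cl)cc1` remains to be measured. It has isobutyl in place of tert-butyl on an amide-type nitrogen. Among the measured compounds shown here, only one measured step bears on this change, and it bears only indirectly: a 2.8-fold lower number from compound 1 to compound 2 (0.45 log units; beyond the scatter), a modest step with tert-butyl in place of phenyl at the same nitrogen. For the measured compounds named here, no measured compound carries isobutyl, and the new change only rejoins the same atoms differently, so a smaller step than that one is expected, one within the scatter. The estimated step is a 1.1-fold higher number from compound 2 to compound 3 (0.05 log units; within the scatter). Compound 3 is expected at 10000 nM, with an estimated range of 4500 nM to 22000 nM.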

Compound 3, half-maximal inhibitory concentration: 21000 nM
Beside the measured number, compound 3's estimate is 2.1-fold (0.32 log units) below it, and the stated range covers the measured number.
By their numbers in this assay, from the lowest: compound 2; then compounds 3 and 1 (each within the scatter of the next).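

In this assay, the amide-type nitrogen proves sensitive to how the same atoms are arranged within its substituent, not only to the kind of group it carries: the change to isobutyl gives a 2.4-fold higher number from compound 2 to compound 3 (0.38 log units; beyond the scatter) and this step lies beyond the scatter. Isobutyl does not keep the advantage that tert-butyl showed over phenyl, as the comparison with the phenyl amide gives a 1.2-fold lower number from compound 1 to compound 3 (0.08 log units; within the scatter) and this step lies within the scatter, so tert-butyl alone stands apart among these three groups. No measurement offered here accounts for this difference.

From the compounds shown here alone, it remains open whether a cyclopropyl group or a longer straight chain such as n-butyl on this nitrogen would track tert-butyl or isobutyl. Also open, going by these compounds, is how a chain ending in an amine or a carboxylic acid would fare here.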